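This account rests on a few compounds, and the source may have more. Where it says the series, first, only, none or still open, it means among the compounds named here.

Compound 1 `CCCCc1cc2cn(COCCO)c(=O)nc2o1`: > 400000 nM
Compound 2 `CCCCCCCCCc1cc2cn(COCCO)c(=O)nc2o1`: >= 16000 nM

In a functional assay on HEL cells (Homo sapiens), read by microscopy (a lower number here means that less compound is tolerated, a higher number that more compound is tolerated), compound 1 gives > 400000 nM, which is a limit of the assay and not a number. Compound 2 gives >= 16000 nM, likewise a limit. Among the compounds with values here, the one measured step, a step that the two limits leave unreadable from compound 1 to compound 2, is therefore unreadable. Compound 3 `O=c1nc2occc2cn1COCCO` differs from compound 1 by hydrogen in place of butyl on an aromatic carbon. Within the data shown here, no measured step bears on this change, and the only related step cannot be read, so no shift beyond the scatter is expected. Compound 3 is expected near 400000 nM, between 100000 nM and 1000000 nM, a step of a number no higher from compound 1 to compound 3 (the limit leaves the size open), most likely reported again only as a limit.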

Compound 3, minimum cytotoxic concentration: > 400000 nM
Compound 3 was reported as a limit; the forecaster's own chance of this, stated with the estimate: 85%; the middle value lies on the limit itself.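

Compound 1 and compound 3 are both reported only as limits, so no step can be read between them. The compounds shown leave open whether butyl in place of hydrogen changes the tolerated concentration at all.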